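The source may report more compounds than this note shows. Statements on the series, on what has been measured and on what is new or still open speak of the compounds shown alone.

Of the compounds shown here, three of a shared core have been measured in a functional assay on HCT-116 cells (Homo sapiens) for cytotoxicity, read by MTT assay, with a stated time of 72 h; on this read-out higher numbers stand for weaker inhibition and lower numbers for stronger inhibition. Compound 1 `Cc1ccc(CSc2cc(Cl)c(C)cc2S(=O)(=O)/N=C(\N)n2nc(C)cc2-c2ccccc2)cc1` gives 28000 nM, the highest of the three numbers. Compound 2 `Cc1cc(S(=O)(=O)/N=C(\N)n2nccc2-c2ccccc2)c(SCc2ccccc2)cc1Cl` gives 12000 nM, a number beyond the scatter from that of compound 1, while compound 3 `Cc1cc(S(=O)(=O)/N=C(\N)n2nccc2-c2ccccc2)c(SCc2ccc(C(F)(F)F)cc2)cc1Cl` gives 14000 nM, which lies within the scatter of compound 1. For the measured compounds named here, the one step within this set, a 1.2-fold higher number from compound 2 to compound 3 (0.07 log units; within the scatter), changes the same ring that is altered here. Compound 4 `Cc1cc(-c2ccccc2)n(/C(N)=N/S(=O)(=O)c2cc(C)c(Cl)cc2SCc2ccccc2C)n1` differs from compound 1 only in that (2-methylphenyl in place of 4-methylphenyl on a saturated chain carbon bound to a sulfur). Going by the values given here, no measured step covers moving a methyl on that ring, so compound 4 is expected to stay close to compound 1, with a 1.1-fold lower number from compound 1 to compound 4 (0.03 log units; within the scatter), at an estimated 26000 nM in this assay, in the range 11000 nM to 60000 nM.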

Compound 4, half-maximal inhibitory concentration: 42000 nM
For compound 4 the middle estimate is 1.6-fold (0.21 log units) below the measured one; the measured number falls inside the stated range.
By their numbers in this assay, from the lowest: compounds 2, 3, 1 and 4 (each within the scatter of the next, the first and the last beyond it).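

In this assay, moving the methyl around the ring gives a 1.5-fold higher number from compound 1 to compound 4 (0.18 log units; within the scatter). For the compounds shown here, this is the first measured change in where a group sits on this ring, rather than in which group is present, and the two placements cannot be told apart in this read-out. Nothing measured here offers an explanation for this result. Going by these compounds, whether an amine or a carboxylic acid on this ring would shift the number beyond the scatter remains open, as does the effect of a longer chain in place of the methyl.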